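The source may hold more compounds than are shown below. What is called first, only, known or untested is meant among the compounds shown, and "the series" means these compounds.

Measured so far:
- Compound 1, `C=CCOc1c(C)c(C)c2c(c1C)CCC(C)(COc1ccc(/C=C3\SC(=O)NC3=O)cc1C)O2`: in a functional assay on MCF7 cells (Homo sapiens), tested at 5 uM (on this read-out lower numbers stand for a stronger effect and higher numbers for a weaker effect at the one concentration tested), compound 1 gives 24%
- Compound 2, `CC(C)=CCOc1c(C)c(C)c2c(c1C)CCC(C)(COc1ccc(/C=C3\SC(=O)NC3=O)cc1-c1ccc(F)cc1)O2`: in this assay compound 2 gives 92%

Compound 2 stands as the higher, that is the weaker, of the two numbers in this assay; the nearest value is that of compound 1, which lies lower by a gap beyond the usual scatter. Going by the values given here, no step between measured compounds that differ in a single place is available, so the two values show only that the pair differs strongly, not which part of the structure carries the difference.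

The next compound, compound 3, `CC(C)=CCOc1c(C)c(C)c2c(c1C)CCC(C)(COc1ccc(/C=C3\SC(=O)NC3=O)cc1)O2`, keeps the core of compound 2 and changes one place: hydrogen in place of 4-fluorophenyl on an aromatic carbon.

Among the compounds with values here, no measured step covers this change. Compound 1, which also carries no 4-fluorophenyl at that place, is the only pointer, and it sits at the strong end of the read-out. A step of a number 52 percentage points lower from compound 2 to compound 3 (beyond the scatter) is therefore expected, downward and beyond the scatter. For compound 3 in this assay the estimate is 40%, with a range from 15% to 75%.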

Compound 3, a percentage reported as activity, at one concentration (the size of the read-out at that concentration, not a potency): 21%
Estimate against measurement, compound 3: 19 percentage points above; low and high end bracket the measured number.
By their numbers in this assay, from the lowest: compounds 3 and 1 (each within the scatter of the next); then compound 2.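

In this assay, going by these compounds alone, hydrogen in place of 4-fluorophenyl on this aromatic carbon gives a number 71 percentage points lower from compound 2 to compound 3 (beyond the scatter) and is the first single-place step, so for this pair the large gap can be assigned to this one position. With the rest of the structure held constant, the 4-fluorophenyl group at this place, ortho to a large group, goes with the weak end of the read-out, while compound 3 with hydrogen gives 21% at the one concentration tested. No measurement bearing on the reason for this step is at hand.

As far as these compounds go, whether the weak effect belongs to 4-fluorophenyl in particular or to other substituents on this carbon stays open; a chlorine atom, a methoxy group, an unsubstituted phenyl ring or an amine here would help to separate those cases. The chain on the ether oxygen of the shared core and the group on this carbon both differ between compound 1 and compound 3, so the share of each cannot be read from these values.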